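A few compounds are considered here, and "the series" means these few. Any claim that something is new, unique, unknown or untested is made for them only; others in the source may bear on it.

Measured so far:
compound 1, `CC(C)n1cc(-c2ccnc3[nH]c(C4CCNCC4)cc23)ccc1=O`, in a physicochemical assay for solubility, in phosphate buffer, at pH 7.4 (on this read-out lower numbers stand for lower solubility and higher numbers for higher solubility), gives 910000 nM
compound 2, `COc1cc(F)ccc1-c1ccnc2[nH]c(C3CCN(CC(=O)N(C)C)CC3)cc12`, in this assay gives 38000 nM

Compound 2 stands lowest of the two numbers; its nearest neighbour is compound 1, whose number is higher by a margin beyond the scatter. Among the compounds with values here, no pair of measured compounds differs in a single place, so no measured step is available.

Compound 3, `CC(C)n1cc(-c2ccnc3[nH]c(C4CCN(CC(=O)N(C)C)CC4)cc23)ccc1=O`, is not yet measured. It differs from compound 2 as follows: a group of 10 heavy atoms (8 carbon, 1 nitrogen, 1 oxygen; one six-membered aromatic ring with 1 hetero atom) in place of a group of 9 heavy atoms (7 carbon, 1 oxygen, 1 fluorine; one six-membered aromatic ring of carbon only), on an aromatic carbon. Within the data shown here, the group that enters is the one carried by compound 1, whose value is 910000 nM, but compound 1 also differs from compound 2 elsewhere, so that comparison alone does not fix the size of the step.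

The step that is expected here is a 5.3-fold higher number from compound 2 to compound 3 (0.72 log units; beyond the scatter). That expected step would be upward and beyond the scatter, though smaller than the gap between compound 2 and compound 1. For compound 3 the estimated value is 200000 nM, with a range from 60000 nM to 600000 nM.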

Compound 3, solubility: 110000 nM
Beside the measured number, compound 3's estimate is 1.8-fold (0.26 log units) above it, within the range that was stated.
By their numbers in this assay, from the lowest: compound 2; then compound 3; then compound 1.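

In this assay, within the data shown here, putting the group carried by compound 3 in place of 4-fluoro-2-methoxyphenyl, on the aromatic carbon opposite the ring nitrogen, gives a 2.9-fold higher number from compound 2 to compound 3 (0.46 log units; beyond the scatter), which is the first reading of this position with the rest of the molecule unchanged. The second pair isolates the other place: (dimethylcarbamoyl)methyl in place of hydrogen on the ring amine nitrogen gives an 8.3-fold lower number from compound 1 to compound 3 (0.92 log units; beyond the scatter), so the number in this assay moves beyond the scatter with a change at either place, and compound 3 falls between the other two. No measurement at hand accounts for the size or direction of either step.

Going by these compounds, each step has been read against only one partner, so it remains open whether the step at the aromatic carbon keeps its size when the ring amine nitrogen carries hydrogen. Also open, on these data alone, is how the number responds to other groups on that nitrogen, such as a carboxylic acid or a longer chain ending in a tertiary amine, or to a morpholine on the aromatic carbon.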